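The compounds below may be only part of what the source reports. "The series", "measured", "known", "first", "only" and "open" are said of these compounds alone.

Measured so far:
- compound 1, `CCCN(CC1CC1)c1nc(CC)c(-c2ccc(Cl)cc2Cl)nc1CC`: 0.2 h
- compound 2, `CCc1nc(-c2ccc(OC)nc2OC)c(CC)nc1NC(CC)CC`: 0.15 h

Both numbers come from an in vitro ADME assay on microsomes (Homo sapiens) for metabolic stability; a lower number here means that the compound disappears faster, a higher number that the compound lasts longer. In this assay compound 1 gives 0.2 h and compound 2 gives 0.15 h; the two values sit within the scatter of each other, so no order between them can be drawn, and neither compound stands apart from the other. Both half-lives are short.

The next compound, compound 3, `CCCN(CCN(C)C)c1nc(CC)c(-c2ccc(Cl)cc2Cl)nc1CC`, keeps the core and the propyl group of compound 1 and differs in one place: (dimethylamino)methyl in place of cyclopropyl on a saturated chain carbon bound to a nitrogen on an aromatic ring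

Within the data shown here, no pair of measured compounds carries this change, so there is no step to lean on. Among the measured compounds shown here, the only anchor is compound 1 with 0.2 h in this assay. Without a comparable step, the expected size of the step from compound 1 to compound 3 is none beyond the scatter, in either direction, no change at the digits printed from compound 1 to compound 3 (within the scatter). Compound 3 is thus expected at about 0.2 h in this assay, with a range from 0.1 h to 0.45 h.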

Compound 3, half-life: 0.0833 h
The estimate for compound 3 lay 2.4-fold (0.38 log units) above the measured number; the measured number lies below the stated range.
By their numbers in this assay, from the lowest: compounds 3, 2 and 1 (each within the scatter of the next, the first and the last beyond it).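

In this assay, (dimethylamino)methyl in place of cyclopropyl on a saturated chain carbon bound to a nitrogen on an aromatic ring gives a 2.4-fold lower number from compound 1 to compound 3 (0.38 log units; beyond the scatter), so the half-life does respond to what stands at this place, and this change moves it towards faster disappearance. The change removes the three-membered ring and brings in a nitrogen with one hydrogen-bond acceptor in a single step, so this one pair cannot separate the loss of the ring from the gain of the dimethylamino group. Nothing at hand accounts for the shift in half-life.

On these data alone, it remains open whether a methoxymethyl group, which keeps a heteroatom but carries no amine, or a plain ethyl group, which carries neither ring nor heteroatom, would stay close to compound 1 at 0.2 h or fall towards compound 3 at 0.0833 h. Also open, as far as these compounds go, is whether a cyclic amine such as morpholine at the same place would follow the dimethylamino group, and whether the same change on another core would give a step of similar size.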